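The compounds below may be only part of what the source reports. "The series", "measured", "known", "first", "only" and "open" are said of these compounds alone.

Measured in a functional assay on HEL cells (Homo sapiens) for cytotoxicity; a lower number here means that less compound is tolerated, a higher number that more compound is tolerated:
- compound 1 `CO[C@@H]1[C@@H](OC)[C@H](Cc2ccccc2)O[C@@H]2CO[C@@H](c3ccccc3)O[C@@H]12` gives 20 ug/mL
- compound 2 `O[C@@H]1[C@@H](O)[C@H](c2ccccc2)O[C@@H]2CO[C@@H](c3ccc(C(F)(F)F)cc3)O[C@@H]12` gives 400 ug/mL
- compound 3 `CO[C@@H]1[C@@H](OC)[C@H](c2ccccc2)O[C@@H]2CO[C@@H](c3cccs3)O[C@@H]12` gives "not determined" (no result reported)

Compound 1 and compound 2 differ from each other in several places at once, so their two values show only the span the series has covered so far, and nothing more can be read from them about any single change. Compound 3 stands without a number in this assay; nothing is known of where it falls.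

Compound 4 `CO[C@@H]1[C@@H](OC)[C@H](c2ccccc2)O[C@@H]2CO[C@@H](c3cccc(Cl)c3)O[C@@H]12` is the next compound to be measured. It differs from compound 3 by 3-chlorophenyl in place of thiophen-2-yl on a saturated ring carbon. Among the measured compounds shown here, with no measured step for this kind of change anywhere, no direction can be given for it beyond the scatter; a middle position within the span seen for compound 1 and compound 2 is the only reasonable working assumption. Compound 4 is therefore expected to give about 100 ug/mL in this assay, within a range of 20 ug/mL to 400 ug/mL.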

Compound 4, minimum cytotoxic concentration: >= 40 ug/mL
Compound 4 ended at the assay's limit; the forecaster's own chance of this, stated with the estimate: 20%; the middle value lies beyond the limit too.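

No step can be read from compound 3 to compound 4: compound 3 has no single number, and the result for compound 4 is a limit, not a number. The compounds shown leave open how 3-chlorophenyl in place of thiophen-2-yl alters tolerated concentration.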